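From compound 1 to compound 3: one group swapped

The compounds below may be only part of what the source reports. "The series", "measured", "known", "first", "only" and "open" are said of these compounds alone.

For the measured compounds named here, in a functional assay on PC-3 cells (Homo sapiens) for antiproliferative activity, read by MTT assay, with a stated time of 72 h (on this read-out lower numbers stand for stronger inhibition and higher numbers for weaker inhibition), compound 1 `C#CCSc1nc(Sc2nnnn2CCN(C)C)c(C#N)c(-c2ccc(Cl)cc2)n1` gives 7170 nM, the only actual number so far. Compound 2 `C#CCSc1nc(Sc2nc[nH]n2)c(C#N)c(-c2cc(OC)c(OC)c(OC)c2)n1` reads > 20000 nM, which is a limit of the assay and not a number. Compound 3 `C#CCSc1nc(Sc2nccs2)c(C#N)c(-c2ccc(Cl)cc2)n1` keeps the core of compound 1 but carries 1,3-thiazol-2-yl in place of 1-(2-(dimethylamino)ethyl)-1H-tetrazol-5-yl on a sulfur. Going by the values given here, no measured pair shows what such a swap does, so the expected step in this assay is a 1.2-fold lower number from compound 1 to compound 3 (0.08 log units; within the scatter), none beyond the scatter. For compound 3 the estimated value is 6000 nM, with an expected range from 1500 nM to 20000 nM.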

Compound 3, half-maximal inhibitory concentration: 3620 nM
Beside the measured number, compound 3's estimate is 1.7-fold (0.22 log units) above it; the measured number falls inside the stated range.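

For the compounds shown here, the first pair that can be read in this assay shows a 2.0-fold lower number from compound 1 to compound 3 (0.30 log units; within the scatter) when 1,3-thiazol-2-yl takes the place of 1-(2-(dimethylamino)ethyl)-1H-tetrazol-5-yl on a sulfur. The two values lie within the scatter of each other, so on this evidence the position accepts a ring with fewer hetero atoms and no dimethylamino chain while the activity stays at the same level. From the compounds shown here alone, whether a carboxylic acid or a simple amine on that sulfur would keep this level remains open. Nothing shown explains why the swap leaves the two values so close.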